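A few compounds are considered here, and "the series" means these few. Any claim that something is new, unique, unknown or untested is made for them only; others in the source may bear on it.

Of the compounds shown here, three built on one shared core have been tested in a functional assay on SGC-7901 cells (Homo sapiens) for cytotoxicity, read by MTT assay, with a stated time of 48 h; a higher number here means a weaker inhibitor, a lower number a stronger inhibitor: compound 1 `O=C(CSc1ccccc1)N1N=C(c2cc3ccccc3oc2=O)C[C@@H]1c1ccccc1` gives 20300 nM, compound 2 `O=C(CSc1ccc([N+](=O)[O-])cc1)N1N=C(c2cc3ccccc3oc2=O)C[C@@H]1c1ccccc1C(F)(F)F` gives 9770 nM, and compound 3 `O=C(CSc1ccc(Br)cc1)N1N=C(c2cc3ccccc3oc2=O)C[C@@H]1c1ccccc1C(F)(F)F` gives 14700 nM. The number for compound 3 lies within the usual scatter of both the others. Compound 4 `O=C(CSc1ccc(Br)cc1)N1N=C(c2cc3ccccc3oc2=O)C[C@@H]1c1ccccc1` differs from compound 3 in one place, with hydrogen in place of trifluoromethyl on an aromatic carbon, ortho to a large group (hydrogen in place of trifluoromethyl on an aromatic carbon). Among the measured compounds shown here, no measured step covers this exact change. For the measured compounds named here, the one step available, a 1.5-fold higher number from compound 2 to compound 3 (0.18 log units; within the scatter), swaps a different group, nitro for bromo, and stays within the scatter. Compound 1 also has no trifluoromethyl, although it has no bromo either, and its 20300 nM sits within the scatter of compound 3. On this thin evidence, no step beyond the scatter is expected in this assay. The expected step is a 1.1-fold higher number from compound 3 to compound 4 (0.04 log units; within the scatter). For compound 4 the estimated value is 16000 nM, with an expected range of 8000 nM to 32000 nM.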

Compound 4, half-maximal inhibitory concentration: 14300 nM
Compound 4: the middle estimate sits 1.1-fold (0.05 log units) above what was measured; measured number inside the range.
By their numbers in this assay, from the lowest: compounds 2, 4, 3 and 1 (each within the scatter of the next, the first and the last beyond it).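

In this assay, going from 2-(trifluoromethyl)phenyl to phenyl gives a 1.0-fold lower number from compound 3 to compound 4 (0.01 log units; within the scatter), so with bromo present, this aromatic carbon can carry either trifluoromethyl or hydrogen with no difference beyond the scatter. Among the compounds shown here, compound 4 also gives the first direct reading of adding bromo, a 1.4-fold lower number from compound 1 to compound 4 (0.15 log units; within the scatter), and this step too stays within the scatter. No measured property is at hand to explain either result.

From the compounds shown here alone, it remains open whether hydrogen in place of trifluoromethyl would give an equally small step in a compound carrying nitro rather than bromo. Going by these compounds, it is also open whether an amine or a carboxylic acid on this same aromatic carbon would move the number beyond the scatter.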